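A few compounds are considered here, and "the series" means these few. Any claim that something is new, unique, unknown or untested is made for them only; others in the source may bear on it.

Working notes on the series. Three compounds of a shared core carry different groups on a double-bonded chain carbon bound to a double-bonded chain carbon. Compound 1 `COc1cc(/C=C/C(=O)/C=C/c2ccco2)ccc1OCc1cn(CCCCOc2cc(=O)oc3ccccc23)nn1` bears furan-2-yl there; in a functional assay on HCT-116 cells (Homo sapiens) for inhibition, read by sulforhodamine B assay, with a stated time of 48 h, tested at 50 uM (on this read-out lower numbers stand for less inhibition of growth and higher numbers for more inhibition of growth at the one concentration tested), compound 1 gives 47%. Compound 2 `COc1cccc(/C=C/C(=O)/C=C/c2ccc(OCc3cn(CCCCOc4cc(=O)oc5ccccc45)nn3)c(OC)c2)c1` bears 3-methoxyphenyl; in this assay compound 2 gives 44%. Compound 3 `COc1cc(/C=C/C(=O)/C=C/c2cccs2)ccc1OCc1cn(CCCCOc2cc(=O)oc3ccccc23)nn1` bears thiophen-2-yl; in this assay compound 3 gives 41%, the lowest of the three numbers, though the steps of a number 6 percentage points lower from compound 1 to compound 3 (within the scatter) and a number 3 percentage points lower from compound 2 to compound 3 (within the scatter) both stay within the scatter, as does a number 3 percentage points lower from compound 1 to compound 2 (within the scatter). On these numbers the three groups at this position are indistinguishable.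

Compound 4 `COc1ccc(/C=C/C(=O)/C=C/c2ccc(OCc3cn(CCCCOc4cc(=O)oc5ccccc45)nn3)c(OC)c2)cc1` is the next member. The change from compound 3 is 4-methoxyphenyl in place of thiophen-2-yl on a double-bonded chain carbon bound to a double-bonded chain carbon. Among the measured compounds shown here, the step that bears most directly is the one from compound 2 to compound 3, a methoxyphenyl giving way to thiophen-2-yl, which moved by a number 3 percentage points lower from compound 2 to compound 3 (within the scatter); the step of a number 6 percentage points lower from compound 1 to compound 3 (within the scatter), another small-ring to thiophen-2-yl swap, was similarly flat. With an aryl again replacing thiophen-2-yl, no movement beyond the scatter is expected in this assay. Compound 4 is therefore estimated at 44%, with a range from 33% to 55%, which means an expected step of a number 3 percentage points higher from compound 3 to compound 4 (within the scatter).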

Compound 4, percent growth inhibition at one concentration: 40%
The estimate for compound 4 lay 4 percentage points above the measured number; the measured number falls inside the stated range.
By their numbers in this assay, from the lowest: compounds 4, 3, 2 and 1 (each within the scatter of the next).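

In this assay the 4-methoxyphenyl group on a double-bonded chain carbon bound to a double-bonded chain carbon cannot be told apart from any of the three earlier groups: the steps of a number 1 percentage points lower from compound 3 to compound 4 (within the scatter) and a number 4 percentage points lower from compound 2 to compound 4 (within the scatter) and a number 7 percentage points lower from compound 1 to compound 4 (within the scatter) are all within the scatter. Among the compounds shown here, the step from 3-methoxyphenyl to 4-methoxyphenyl is the first comparison here of two methoxyphenyl groups, and with the methoxy group's placement on the ring as the only change, it gives no separation at this single concentration. The flat picture now spans four groups, with the five-membered aromatic rings and the six-membered aromatic rings of carbon only all falling within the scatter of one another, and no measurement available here offers an explanation for this flatness.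

The compounds shown leave open whether a group other than an uncharged aromatic ring at this position, such as a cyclohexyl ring, or a phenyl ring carrying a dimethylamino group or a carboxylic acid, would give a step beyond the scatter. They also leave open whether changes elsewhere on the shared core, such as a longer chain in place of the butyl linker, would matter more than this position does.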